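Working notes: chloro in place of ethoxy

The source may report more compounds than this note shows. Statements on the series, on what has been measured and on what is new or still open speak of the compounds shown alone.

- Compound 1 `Cc1ncc([N+](=O)[O-])n1CCSc1nnc(-c2ccc(N)cc2)o1`: 19800 nM
- Compound 2 `CCOc1ccc(-c2nnc(SCCn3c([N+](=O)[O-])cnc3C)o2)cc1`: 16600 nM

Among the compounds with values here, in a functional assay on MCF7 cells (Homo sapiens) for cytotoxicity, read by MTT assay, with a stated time of 48 h (on this read-out higher numbers stand for weaker inhibition and lower numbers for stronger inhibition), compound 2 gives 16600 nM, which puts it level with the only other measured compound, as the two values lie within the scatter of each other. The next change is chloro in place of ethoxy on an aromatic carbon, and it leads to compound 3 `Cc1ncc([N+](=O)[O-])n1CCSc1nnc(-c2ccc(Cl)cc2)o1`. Within the data shown here, one measured step bears on this change: a 1.2-fold lower number from compound 1 to compound 2 (0.08 log units; within the scatter). It concerns the same aromatic carbon, and the swap there left the number within the scatter. Among the measured compounds shown here, no chloro compound has been measured yet, so this single step is thin support. No shift beyond the scatter is therefore expected in this assay, and no direction is favoured. The expected step is a 1.0-fold lower number from compound 2 to compound 3 (0.02 log units; within the scatter). For compound 3 the estimated value is 16000 nM, with an expected range from 7000 nM to 34000 nM.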

Compound 3, half-maximal inhibitory concentration: 18700 nM
Compound 3: the middle estimate sits 1.2-fold (0.07 log units) below what was measured; low and high end bracket the measured number.
By their numbers in this assay, from the lowest: compounds 2, 3 and 1 (each within the scatter of the next).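

In this assay, chloro in place of ethoxy gives (a 1.1-fold higher number from compound 2 to compound 3 (0.05 log units; within the scatter)), and chloro in place of amino gives (a 1.1-fold lower number from compound 1 to compound 3 (0.02 log units; within the scatter)). Within the data shown here, this aromatic carbon, para to a large group, has now carried three different groups with no step beyond the scatter, whereas the earlier pair offered only the single swap of ethoxy for amino; even exchanging ethoxy, with 3 heavy atoms and 1 hydrogen-bond acceptor, for chloro, with 1 heavy atom and 0 hydrogen-bond acceptors, leaves the number within the scatter. No measured evidence is available to account for this flat result.

As far as these compounds go, it remains open whether a carboxylic acid or a longer alkoxy chain on this carbon would move the number beyond the scatter. The compounds shown also leave open what happens when the nitro group on the shared core is replaced.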